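Methoxy for methyl on a thiourea-urea series

This account rests on a few compounds, and the source may have more. Where it says the series, first, only, none or still open, it means among the compounds named here.

Compound 1 `Cc1ccccc1NC(=S)NC(=O)Nc1ccc2c(c1)C(=O)C(=O)N2Cc1ccccc1Cl`: 3.7
Compound 2 `Cc1cccc(NC(=S)NC(=O)Nc2ccc3c(c2)C(=O)C(=O)N3Cc2ccccc2Cl)c1`: 3.72
Compound 3 `Cc1ccc(NC(=S)NC(=O)Nc2ccc3c(c2)C(=O)C(=O)N3Cc2ccccc2Cl)cc1`: 3.73

These values come from a physicochemical assay for lipophilicity, in phosphate buffer, measured as octanol-water partition; on this read-out higher numbers stand for higher lipophilicity and lower numbers for lower lipophilicity. Compound 3 holds the highest of the three numbers, but the steps of a number 0.03 log units higher from compound 1 to compound 3 (within the scatter) and a number 0.01 log units higher from compound 2 to compound 3 (within the scatter) are within the scatter, as is a number 0.02 log units higher from compound 1 to compound 2 (within the scatter), so the three compounds stand level. Compound 4 `COc1ccc(NC(=S)NC(=O)Nc2ccc3c(c2)C(=O)C(=O)N3Cc2ccccc2Cl)cc1` has not been measured; it differs from compound 3 by methoxy in place of methyl on an aromatic carbon. The measured steps only move a methyl around its ring and none exchanges it for a methoxy, so they give no direct guidance on this change. Compound 4 is nevertheless expected to come out a little lower, the estimated step being a number 0.43 log units lower from compound 3 to compound 4 (beyond the scatter). In this assay compound 4 is expected to give 3.3, between 2.9 and 3.7.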

Compound 4, partition coefficient: 3.24
For compound 4 the middle estimate is 0.06 log units above the measured one, and the stated range covers the measured number.
By their numbers in this assay, from the lowest: compound 4; then compounds 1, 2 and 3 (each within the scatter of the next).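

In this assay the exchange of methyl for methoxy moves the number, which shifting the methyl around its ring did not do: a number 0.49 log units lower from compound 3 to compound 4 (beyond the scatter). The other two methyl compounds give the same picture, with a number 0.48 log units lower from compound 2 to compound 4 (beyond the scatter) and a number 0.46 log units lower from compound 1 to compound 4 (beyond the scatter). Among these four compounds, then, which group sits on the ring makes a readable difference, while the place of the methyl does not. Nothing measured here gives a reason for this step. From the compounds shown here alone, how an amine or a carboxylic acid in place of the methyl would read remains open.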